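The compounds below may be only part of what the source reports. "The series", "measured", "known", "first", "only" and "open" are said of these compounds alone.

Measured so far in an in vitro assay on HEK-tsA201 cells for antagonist activity at Neuronal acetylcholine receptor; alpha3/beta4 (Homo sapiens), read by fluorescence and calcium flux; a lower number here means a stronger inhibitor, a higher number a weaker inhibitor:
- compound 1 `C=CCOc1ccc(C(=O)Nc2ccccn2)cc1` gives 61400 nM
- compound 2 `CCCOc1ccc(C(=O)Nc2cccc(Nc3ccc(OC)cc3)n2)cc1` gives only a limit of this assay, > 100000 nM
- compound 3 `CCCOc1ccc(C(=O)Nc2cccc(NCc3ccccc3)n2)cc1` gives only a limit of this assay, > 100000 nM

Among the measured compounds shown here, compound 1 holds the only finite value in the set; the other two results are limits. The step from compound 2 to compound 3, a step that the two limits leave unreadable from compound 2 to compound 3, cannot be read because the limit of > 100000 nM in this assay, at which 2 of the 3 values shown sit, covers both ends of it, so the exchange of benzyl for 4-methoxyphenyl on the ring-bound nitrogen teaches nothing about size or direction.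

Compound 4 `C=CCOc1ccc(C(=O)Nc2cccc(NCCC)n2)cc1` differs from compound 1 by propylamino in place of hydrogen on an aromatic carbon. For the measured compounds named here, no measured pair isolates this change. What the set does show is that compound 2 and compound 3, each carrying an amino substituent on the shared core, both sit at the limit, whereas the unsubstituted compound 1 gives a readable number. On that basis compound 4 is expected to lose activity, with a 1.6-fold higher number from compound 1 to compound 4 (0.21 log units; within the scatter) as the estimated step, and a fair chance that this assay again returns only a limit. The estimate for compound 4 is 100000 nM, in the range 40000 nM to 250000 nM.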

Compound 4, half-maximal inhibitory concentration: 11700 nM
Estimate against measurement, compound 4: 8.5-fold (0.93 log units) above; the measured number lies below the stated range.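

In this assay, propylamino in place of hydrogen on an aromatic carbon, next to the ring nitrogen, gives a 5.2-fold lower number from compound 1 to compound 4 (0.72 log units; beyond the scatter). Among the compounds shown here, this is the first readable step at this position, and it shows that the position accepts a substituent and that, on the core of compound 1, this change gives a stronger inhibitor. Compound 2 and compound 3 differ from compound 4 in more than one place and return only a limit, so they give no comparison for this position: the limit of > 100000 nM in this assay, at which 2 of the 4 values shown sit.

From the compounds shown here alone, whether a free amine, a butylamino chain or a methoxy group at this position would give a step of similar size remains open. Also open, going by these compounds, is how much of the step belongs to the nitrogen and how much to the propyl chain.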